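A few compounds are considered here, and "the series" means these few. Any claim that something is new, unique, unknown or untested is made for them only; others in the source may bear on it.

The series turns on the core shared by compound 1 `O=C(Nc1ncc(Cc2ccc(F)cc2)s1)C1CCCCC1`, compound 2 `COC(=O)CCCCNc1ncc(C(Oc2ccc3cc(Br)ccc3c2)c2ccc(Cl)cc2)s1` and compound 3 `O=C(Nc1ncc(C(Oc2ccc3cc(Br)ccc3c2)c2ccc(Cl)cc2)s1)c1cc(F)c(F)cc1F`, and on how much harm each does to a liver cell line. In an ADME assay on HepG2 2.2.15 cells (Homo sapiens) for cytotoxicity (on this read-out lower numbers stand for higher toxicity in this test and higher numbers for lower toxicity in this test), compound 1 reaches only a limit of the assay, > 50000 nM. The single limit in this set is summarised as the limit of > 50000 nM in this assay, at which 1 of the 2 values shown sits. In this assay compound 2 is recorded as "not toxic" (no number reported), with no number attached, so it stands at the harmless end of what has been seen without a figure to place it against compound 1.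

Compound 3 is not yet measured. It departs from compound 2 in one place ((2,4,5-trifluorophenyl)carbonyl in place of 4-(methoxycarbonyl)butyl on a nitrogen on an aromatic ring).

For the measured compounds named here, with no measured step between any two compounds, there is nothing in the data that sets the size of this move. The expectation in this assay is for a step in the direction of somewhat higher toxicity, but one that may well stay within the usual scatter. Compound 3 is therefore expected to give about 45000 nM, within a range from 12000 nM to 150000 nM.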

Compound 3, half-maximal cytotoxic concentration: "not toxic" (no number reported)
Compound 3: no number reported; the estimate stays without a comparison.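

In this assay, for the compounds shown here, compound 3, like compound 2, is recorded as "not toxic" with no number attached, so no step between compound 2 and compound 3 can be read. Compound 1 alone carries a figure, and that figure is a limit: the limit of > 50000 nM in this assay, at which 1 of the 3 values shown sits.

The compounds shown leave open how far apart in toxicity they lie, and whether (2,4,5-trifluorophenyl)carbonyl in place of 4-(methoxycarbonyl)butyl shifts it at all.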